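The source may hold more compounds than are shown below. What is called first, only, known or untested is meant among the compounds shown, and "the series" means these compounds.

Compound 1 `COc1cc2c(Nc3nc4ccc(C(=O)Nc5c(C)cccc5C)cc4s3)ncnc2cc1OCCCN1CCCCC1` is the weakest of the three measured compounds in a functional assay on K562 cells (Homo sapiens) for cytotoxicity, read by WST assay, with a stated time of 72 h (a lower number here means a stronger inhibitor, a higher number a weaker inhibitor), where compound 1 gives 13700 nM. Compound 2 `COc1cc2c(Nc3nc4ccc(C(=O)Nc5c(C)cc(C)cc5C)cc4s3)ncnc2cc1OCCCN1CCCCC1` gives 9300 nM in this assay, and the step of a 1.5-fold lower number from compound 1 to compound 2 (0.17 log units; within the scatter) stays within the scatter. Compound 3 `COc1cc2c(Nc3nc4ccc(C(=O)Nc5c(C)cc(C)cc5C)cc4s3)ncnc2cc1OCCCN1CCCC1` gives 4300 nM in this assay, and the step of a 2.2-fold lower number from compound 2 to compound 3 (0.34 log units; beyond the scatter) is modest but beyond the scatter, so compound 1 stands highest of the three numbers, beyond the scatter only from compound 3.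

Compound 4 `COc1cc2c(Nc3nc4ccc(C(=O)Nc5c(C)cccc5C)cc4s3)ncnc2cc1OCCCN1CCCCC1C` differs from compound 1 by methyl in place of hydrogen on a saturated ring carbon. Within the data shown here, no measured step adds a methyl to the saturated ring; the only change in that ring, a 2.2-fold lower number from compound 2 to compound 3 (0.34 log units; beyond the scatter), replaces the ring itself, and the methyl added in a 1.5-fold lower number from compound 1 to compound 2 (0.17 log units; within the scatter) sits on an aromatic carbon. Neither step bears closely on this change, so no step beyond the scatter in this assay is expected in either direction. Compound 4 is estimated at 12000 nM in this assay, with a range from 5000 nM to 30000 nM, a step of a 1.1-fold lower number from compound 1 to compound 4 (0.06 log units; within the scatter) expected.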

Compound 4, half-maximal inhibitory concentration: 12300 nM
Estimate against measurement, compound 4: 1.0-fold (0.01 log units) below; low and high end bracket the measured number.
By their numbers in this assay, from the lowest: compound 3; then compounds 2, 4 and 1 (each within the scatter of the next).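

In this assay, methyl in place of hydrogen on a saturated ring carbon, next to the ring nitrogen, gives a 1.1-fold lower number from compound 1 to compound 4 (0.05 log units; within the scatter), so compound 1 and compound 4 cannot be told apart. The earlier compounds shown here changed this part of the molecule only by replacing the whole ring, in a 2.2-fold lower number from compound 2 to compound 3 (0.34 log units; beyond the scatter), whereas here the ring is kept and a single carbon on it is substituted, and this methyl leaves the reading within the scatter. The data shown offer no measurement that would explain this result.

The compounds shown leave open whether a larger or different group on this ring carbon, such as ethyl, hydroxymethyl or a carboxylic acid, would also stay within the scatter. They also leave open whether the same methyl would read alike on the pyrrolidin-1-yl ring of compound 3.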